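Swapping a ring for a hydroxylated chain on the amide side

The compounds below may be only part of what the source reports. "The series", "measured", "known", "first", "only" and "open" are said of these compounds alone.

Compound 2 `CS(=O)(=O)Nc1ccc(CNC(=O)c2ccc(N3CCC3)cc2)c(Cl)c1` gives 13000 nM in an assay on HeLa cells for agonist activity at Bile acid receptor (Homo sapiens), read by a luciferase reporter, with a stated time of 24 h (on this read-out higher numbers stand for an effect only at larger amounts of compound and lower numbers for an effect already at smaller amounts), the highest of the two numbers in hand; its only neighbor, compound 1 `CCS(=O)(=O)Nc1ccc(CNC(=O)c2ccc(C(C)(C)C)cc2)c(Cl)c1` gives 500 nM, a gap beyond the scatter. Compound 3 `CC(C)(O)c1ccc(C(=O)NCc2ccc(NS(C)(=O)=O)cc2Cl)cc1` differs from compound 2 in one spot: 1-hydroxy-1-methylethyl in place of azetidin-1-yl on an aromatic carbon. Among the measured compounds shown here, no measured pair shows this exact change, so the size of the step is uncertain. Because compound 1 reaches 500 nM, compound 3 is expected to give a lower number than compound 2, an 8.7-fold lower number from compound 2 to compound 3 (0.94 log units; beyond the scatter). Compound 3 is estimated at 1500 nM, plausibly between 400 nM and 6000 nM.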

Compound 3, half-maximal effective concentration: 32 nM
Compound 3: the middle estimate sits 47-fold (1.67 log units) above what was measured; measured number outside the range, below it.
By their numbers in this assay, from the lowest: compound 3; then compound 1; then compound 2.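

This position on the aromatic ring proves highly sensitive: 1-hydroxy-1-methylethyl in place of azetidin-1-yl gives a large step (a 410-fold lower number from compound 2 to compound 3 (2.61 log units; beyond the scatter)), even though both groups have 4 heavy atoms. The entering group has no ring and adds a hydrogen-bond donor, so two features change in this single swap. Nothing available here explains the size of the step. Still open, going by these compounds, is whether the hydroxyl or the loss of the ring carries the step, and how a methoxy group on the same chain or a carboxylic acid at this spot would read.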